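The compounds below may be only part of what the source reports. "The series", "measured", "known", "first", "only" and "open" are said of these compounds alone.

In a functional assay on THP-1 cells (Homo sapiens) (on this read-out lower numbers stand for stronger inhibition and higher numbers for weaker inhibition), compound 1 `CCSC[C@@](O)([C@@H](Nc1cccc2nc(C)ccc12)c1ccc(OC)c(F)c1)C(F)(F)F` gives 5.01 nM and compound 2 `CCSC[C@@](O)([C@@H](Nc1cccc2nc(C)ccc12)c1ccc(Cl)c(F)c1OC)C(F)(F)F` gives 1.59 nM, the lower of the two numbers. The next structure, compound 3 `CCSC[C@@](O)([C@@H](Nc1cccc2nc(C)ccc12)c1ccc(Cl)c(F)c1O)C(F)(F)F`, has hydrogen in place of methyl on an oxygen on an aromatic ring, methoxy to hydroxy (hydrogen in place of methyl on an oxygen on an aromatic ring). For the measured compounds named here, the only measured step, a 3.2-fold lower number from compound 1 to compound 2 (0.50 log units; beyond the scatter), exchanges the whole 3-fluoro-4-methoxyphenyl for 4-chloro-3-fluoro-2-methoxyphenyl and never removes this methyl, so it bears only loosely. Little movement in this assay is therefore expected, and the estimated step is a 1.6-fold lower number from compound 2 to compound 3 (0.20 log units; within the scatter), within the scatter. For compound 3 the expected value is 1 nM, with an estimated range of 0.3 nM to 4 nM.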

Compound 3, half-maximal inhibitory concentration in the THP-1 assay: 20 nM
Estimate against measurement, compound 3: 20-fold (1.30 log units) below, outside the stated range (above it).
By their numbers in the THP-1 assay, from the lowest: compound 2; then compound 1; then compound 3.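

The methyl on this oxygen is no spare group: in the THP-1 assay methoxy to hydroxy brings a 13-fold higher number from compound 2 to compound 3 (1.10 log units; beyond the scatter) rather than a quiet change. The loss outweighs the earlier gain from the new aryl pattern, leaving a 4.0-fold higher number from compound 1 to compound 3 (0.60 log units; beyond the scatter) in the THP-1 assay despite the added chloro group. The same change also makes the compound much more polar in a physicochemical assay for lipophilicity; a higher number here means a more lipophilic compound, a lower number a more polar compound: the measured partition coefficient of compound 2, 5.3, and of compound 3, 3.4, a number 1.90 log units lower (beyond the scatter). In the physicochemical assay compound 2 gives 5.3 and compound 3 gives 3.4.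

On these data alone, whether the loss in the THP-1 assay tracks that measured difference or the missing methyl itself stays open with this single pair. So does how an ethoxy group or an amine would read at this place.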